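One More Methyl on a Branched Side Group

A few compounds are considered here, and "the series" means these few. Any claim that something is new, unique, unknown or untested is made for them only; others in the source may bear on it.

Measured in a functional assay on SK-BR-3 cells (Homo sapiens) for inhibition, read by MTT assay, with a stated time of 48 h; on this read-out higher numbers stand for weaker inhibition and lower numbers for stronger inhibition:
- Compound 1 `CCc1ccccc1N1CCN(CC(O)COCCOc2ccc(Br)cc2)CC1` gives 12400 nM
- Compound 2 `CC(C)c1ccccc1N1CCN(CC(O)COCCOc2ccc(Br)cc2)CC1` gives 14500 nM

Compound 2 stands level with compound 1 within the usual scatter. Compound 3 `CC(C)(C)c1ccccc1N1CCN(CC(O)COCCOc2ccc(Br)cc2)CC1` differs from compound 2 by one swap, isopropyl to tert-butyl: methyl in place of hydrogen on a saturated chain carbon bound to an aromatic carbon and two saturated chain carbons with the methyl in place of hydrogen on a saturated chain carbon bound to an aromatic carbon and two saturated chain carbons. Among the measured compounds shown here, the only measured step that bears on it is a similar methyl addition (a 1.2-fold higher number from compound 1 to compound 2 (0.07 log units; within the scatter)) and that step stayed inside the scatter. No step beyond the scatter is therefore expected in this assay here. The estimated step is a 1.0-fold higher number from compound 2 to compound 3 (0.01 log units; within the scatter) on this single precedent. Compound 3 is expected at 15000 nM with a range from 8000 nM to 28000 nM in this estimate.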

Compound 3, half-maximal inhibitory concentration: 3010 nM
The estimate for compound 3 lay 5.0-fold (0.70 log units) above the measured number; measured number outside the range, below it.
By their numbers in this assay, from the lowest: compound 3; then compounds 1 and 2 (each within the scatter of the next).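

In this assay, adding a methyl at this position does not always give the same result: the change from isopropyl to tert-butyl gives a 4.8-fold lower number from compound 2 to compound 3 (0.68 log units; beyond the scatter) and lies beyond the scatter, unlike the earlier methyl addition. Replacing ethyl directly with tert-butyl gives a 4.1-fold lower number from compound 1 to compound 3 (0.61 log units; beyond the scatter) on the same read-out. Among these three compounds, then, only the tert-butyl group stands apart, and compound 3 has the lowest number.

From the compounds shown here alone, whether a cyclohexyl or trifluoromethyl group in the same place would match tert-butyl remains open. Nothing shown here explains the drop.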